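This account rests on a few compounds, and the source may have more. Where it says the series, first, only, none or still open, it means among the compounds named here.

Measured in an assay on a protein complex for inhibition of CDK8/Cyclin C (Homo sapiens), with a stated time of 1 h, tested at 10 uM; a lower number here means less inhibition, a higher number more inhibition at the concentration tested (going by the name of the read-out):
- compound 1 `O=C(COc1ccncc1-c1ccc2ccccc2c1)N1CCOCC1`: 9%
- compound 2 `O=C(O)COc1ccncc1-c1ccc2ccccc2c1`: 16%
- compound 3 `CNC(=O)/C=C/c1ccncc1-c1ccc2[nH]ccc2c1`: 100%

Among the compounds with values here, compound 2 sits close to compound 1 and far from compound 3, the only compound of the three with a strong read-out; compound 3 differs from compound 2 in more than one place, so no single step is drawn for that pair, and its value only marks how far the series can reach. Within the data shown here, the one drawn step, a number 7 percentage points higher from compound 1 to compound 2 (within the scatter), touches the carbonyl carbon of the side chain and stays within the scatter.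

Compound 4 `COC(=O)CCc1ccncc1-c1ccc2ccccc2c1` changes the side chain at the aromatic carbon: 2-(methoxycarbonyl)ethyl in place of carboxymethoxy on an aromatic carbon. Among the measured compounds shown here, no measured step bears on this exchange directly; the one available step, from compound 1 to compound 2, concerns a different part of the same chain and was small. Nothing here supports a step beyond the scatter in either direction, so for compound 4 an essentially flat step a number 2 percentage points lower from compound 2 to compound 4 (within the scatter) is expected. The estimate for compound 4 is 14%, with a range from 0% to 35%.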

Compound 4, a percentage reported as inhibition, at one concentration (the size of the read-out at that concentration, not a potency): 98%
Estimate against measurement, compound 4: 84 percentage points below, outside the stated range (above it).
By their numbers in this assay, from the lowest: compounds 1 and 2 (each within the scatter of the next); then compounds 4 and 3 (each within the scatter of the next).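

At the aromatic carbon opposite the ring nitrogen, and ortho to a large group, the read-out in this assay proves highly sensitive to the side chain: the exchange of carboxymethoxy for 2-(methoxycarbonyl)ethyl gives a number 82 percentage points higher from compound 2 to compound 4 (beyond the scatter) and so opens a far larger gap than the earlier change at the carbonyl carbon of the chain. The exchange alters several things at once, since the hydrogen-bond donors go from 1 to 0 and the heavy atoms from 5 to 6, and the oxygen attached to the aromatic carbon gives way to carbon. No measurement at hand accounts for the size of this step.

Which of these alterations carries the step stays open. A carboxylic acid on the same ethyl chain would separate the end group from the linking atom, and an amide or a longer chain would show how far the ester can be varied.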